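A Piperidine in Place of a Polyamine Tail

The source may report more compounds than this note shows. Statements on the series, on what has been measured and on what is new or still open speak of the compounds shown alone.

Compound 1 `CN(C)CCN(CCN(C)C)c1ccc(C(=O)N2CCc3ccc(OS(N)(=O)=O)cc3C2)cc1` was examined in an assay on HEK293 cells for inhibition of Steryl-sulfatase (Homo sapiens), tested at 1 uM (a higher number here means a stronger effect of the compound at the concentration tested, a lower number a weaker effect), where compound 1 gives 15.9%. Among the three measured compounds this is the second highest number: compound 2 `NS(=O)(=O)Oc1ccc2c(c1)CN(C(=O)c1cccc(N3CCC(N4CCCCC4)CC3)c1)CC2`, with 8%, lies within the usual scatter of compound 1, while compound 3 `CCN(Cc1ccccc1)c1cccc(C(=O)N2CCc3ccc(OS(N)(=O)=O)cc3C2)c1`, with 69%, lies well beyond it. Compound 4 `NS(=O)(=O)Oc1ccc2c(c1)CN(C(=O)c1ccc(N3CCCCC3)cc1)CC2` has not yet been measured. It differs from compound 1 in a single place: piperidin-1-yl in place of bis(2-(dimethylamino)ethyl)amino on an aromatic carbon. Among the measured compounds shown here, no pair of measured compounds isolates this change, so any expectation rests on the surrounding numbers. The expected step of a number 19.1 percentage points higher from compound 1 to compound 4 (beyond the scatter) is upward and beyond the scatter, given that compound 3 reaches 69%. Compound 4 is therefore estimated at 35%, within a range from 10% to 65%.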

Compound 4, a percentage reported as inhibition, at one concentration (the size of the read-out at that concentration, not a potency): 38.3%
Compound 4: the middle estimate sits 3.3 percentage points below what was measured; measured number inside the range.
By their numbers in this assay, from the lowest: compounds 2 and 1 (each within the scatter of the next); then compound 4; then compound 3.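

Among the compounds shown here, on this aromatic carbon, para to a large group, the step of a number 22.4 percentage points higher from compound 1 to compound 4 (beyond the scatter) is the first reading of a single change at this position. It shows that bis(2-(dimethylamino)ethyl)amino is not required for the effect at the concentration tested, and that piperidin-1-yl, with fewer heavy atoms and a ring, does better here. Nothing available explains this step. From the compounds shown here alone, whether the gain follows from the ring or from the smaller group stays open. A diethylamino group or a morpholine ring on the same carbon would help to separate the two.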